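A few compounds are considered here, and "the series" means these few. Any claim that something is new, unique, unknown or untested is made for them only; others in the source may bear on it.

Compound 1 `Cc1c(S(=O)(=O)N/C(=N\O)Nc2ccc(Cl)cc2)sc2ccc(Cl)cc12` gives 140 ug/mL in a functional assay on HepG2 cells (Homo sapiens) for cytotoxicity; a higher number here means a weaker inhibitor, a lower number a stronger inhibitor. Compound 2 `Cc1c(S(=O)(=O)N/C(=N\O)Nc2ccc(Cl)c(Cl)c2)sc2ccc(Cl)cc12` reaches only a limit of this assay, > 300 ug/mL. The step of an at least 2.1-fold higher number from compound 1 to compound 2 (0.33 log units; beyond the scatter) rests on the change (chloro in place of hydrogen on an aromatic carbon), and it is bounded by the limit of > 300 ug/mL in this assay, at which 1 of the 3 values shown sits. Compound 3 `Cc1c(S(=O)(=O)/N=C(\S)Nc2ccc(Cl)cc2)sc2ccc(Cl)cc12` shares the chloro pattern of compound 1 on the aniline side but carries a different core; the difference between the two cores is not broken down here. In this assay compound 3 gives 57 ug/mL, the lowest of the two numbers. Compound 4 `Cc1c(S(=O)(=O)/N=C(\S)Nc2ccc(Cl)c(Cl)c2)sc2ccc(Cl)cc12` repeats the same change on the core of compound 3, (chloro in place of hydrogen on an aromatic carbon). Because compound 1 moved by an at least 2.1-fold higher number from compound 1 to compound 2 (0.33 log units; beyond the scatter), a step of similar size, a 2.6-fold higher number from compound 3 to compound 4 (0.42 log units; beyond the scatter), is expected for compound 4. The estimate for compound 4 is 150 ug/mL, from 70 ug/mL to 300 ug/mL.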

Compound 4, half-maximal inhibitory concentration: 62 ug/mL
Estimate against measurement, compound 4: 2.4-fold (0.38 log units) above, and the stated range ends above it.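

Carried to the core of compound 3, the change from 4-chlorophenyl to 3,4-dichlorophenyl gives a 1.1-fold higher number from compound 3 to compound 4 (0.04 log units; within the scatter) in this assay, so no shift is resolved on this core. This does not show that the change behaves differently on the two cores, nor that it carries over between them unaltered: the same change on two cores in this assay, an at least 2.1-fold higher number (0.33 log units; beyond the scatter) from compound 1 to compound 2 and a 1.1-fold higher number (0.04 log units; within the scatter) from compound 3 to compound 4; the limit leaves it open whether they differ The value of compound 2, > 300 ug/mL, is a limit of the assay and not a number.

Open, as far as these compounds go, is whether a group other than chloro on the same aromatic carbon, such as methoxy or a carboxylic acid, would behave alike on both cores. Going by these compounds alone, with only two matched pairs, any reading across further cores also remains open.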